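Methoxy for fluoro on the sulfanyl-linked phenyl of compound 1

The compounds below may be only part of what the source reports. "The series", "measured", "known", "first", "only" and "open" are said of these compounds alone.

Working notes on the series, which shares one core bearing two amino groups and a phenyl substituent. Compound 1 is `Nc1cc(N)c2nc(-c3ccccc3)c(Sc3ccc(F)cc3)nc2c1`. In a functional assay on IGROV-1 cells (Homo sapiens) for inhibition, read by sulforhodamine B assay, with a stated time of 48 h (on this read-out lower numbers stand for higher toxicity in this test and higher numbers for lower toxicity in this test), compound 1 gives only a limit, < 100000 nM. So compound 1 stands nowhere definite on the numbers shown: it sits at the limit of < 100000 nM in this assay, at which 2 of the 3 values shown sit.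

Compound 2 is `COc1ccc(CNc2nc3cc(N)cc(N)c3nc2-c2ccccc2)cc1OC`, and in this assay compound 2 likewise reaches only a limit, < 100000 nM. Compound 3 is `COc1ccc(CNc2nc3cc(N)cc(N)c3nc2-c2ccccc2)cc1`; in this assay compound 3 gives 56200 nM. The step that the limit leaves unreadable from compound 2 to compound 3 is therefore of unreadable size, and no other measured step is shown.

Compound 4 is `COc1ccc(Sc2nc3cc(N)cc(N)c3nc2-c2ccccc2)cc1`. It differs from compound 1 in one place: methoxy in place of fluoro on an aromatic carbon. For the measured compounds named here, no measured step bears directly on this change; the only methoxy-carrying compound with a number, compound 3, carries that group on a different linker and gives a value close to the limit. The expectation is thus weak and amounts to no step beyond the scatter that could be read from compound 1.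

For compound 4 the estimated value in this assay is 50000 nM, with an expected range from 15000 nM to 100000 nM. The step this estimate implies, a step that the limit leaves unreadable from compound 1 to compound 4, is an expectation only, since compound 1 is itself a limit.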

Compound 4, concentration lethal to 50% of the cells: < 100000 nM
Compound 4: a limit, no number (the forecaster's own chance of this, stated with the estimate: 40%); the middle value does not contradict the limit.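

In this assay compound 4 gives < 100000 nM, which is a limit, as is the result for compound 1, so no step can be read between compound 1 and compound 4: the limit of < 100000 nM in this assay, at which 3 of the 4 values shown sit.

Going by these compounds, whether methoxy and fluoro on the sulfanyl-linked phenyl differ at all in this assay stays open.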